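The source may report more compounds than this note shows. Statements on the series, on what has been measured and on what is new or still open speak of the compounds shown alone.

The measured compounds in a functional assay on HCT-116 cells (Homo sapiens) for antiproliferative activity, read by MTT assay, with a stated time of 48 h (a lower number here means a stronger inhibitor, a higher number a weaker inhibitor), are these three.
Compound 1 `Cc1ccccc1-n1nncc1CN1C(=O)C2(C(C#N)=C(N)Oc3c2c2nc4ccccc4nc2c2ccccc32)c2ccccc21` gives > 50000 nM, which is a limit of the assay and not a number.
Compound 2 `N#CC1=C(N)Oc2c(c3nc4ccccc4nc3c3ccccc23)C12C(=O)N(Cc1cnnn1-c1ccc([N+](=O)[O-])cc1)c1ccccc12` gives > 50000 nM, again a limit.
Compound 3 `N#CC1=C(N)Oc2c(N)cc3nc4ccccc4nc3c2C12C(=O)N(Cc1cnnn1-c1ccc(F)cc1)c1ccccc12` gives > 50000 nM, also a limit.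

Going by the values given here, every value recorded so far is therefore (the limit of > 50000 nM in this assay, at which 3 of the 3 values shown sit), and no compound has yet produced a measurable number. Among the compounds with values here, the only pair that differs in a single place is compound 1 and compound 2, where a step that the two limits leave unreadable from compound 1 to compound 2: because both ends are limits, the step has no readable size. Compound 3 thus stands on a limit alone, with nothing stronger or weaker to compare it against.

Compound 4 `CCOc1ccccc1-n1nncc1CN1C(=O)C2(C(C#N)=C(N)Oc3c(N)cc4nc5ccccc5nc4c32)c2ccccc21` is built from compound 3 by one change: 2-ethoxyphenyl in place of 4-fluorophenyl on an aromatic nitrogen. Within the data shown here, no measured step tells how exchanging one aryl group for another on this aromatic nitrogen moves this assay, since the one step of that kind is unreadable. Among the measured compounds shown here, the only guide is that all three measured values sit at the limit. On that basis the step of a number no higher from compound 3 to compound 4 (the limit leaves the size open) is expected to be none beyond the scatter, and compound 4 is estimated at 50000 nM, with a range from 15000 nM to 200000 nM, most likely again reported only as a limit.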

Compound 4, half-maximal inhibitory concentration: > 50000 nM
Compound 4 was reported as a limit; the forecaster's own chance of this, stated with the estimate: 85%; the middle value lies on the limit itself.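

Going by these compounds alone, compound 3 and compound 4 both sit at a limit and not at a number, so the exchange of 4-fluorophenyl for 2-ethoxyphenyl has no readable size, and neither has any other step so far. All four compounds stand at the same limit: the limit of > 50000 nM in this assay, at which 4 of the 4 values shown sit. In this assay the compounds shown leave open which change to the shared core, if any, would give a measurable number.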